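Ether group variation on the shared core: compound 2 to compound 4

A few compounds are considered here, and "the series" means these few. Any claim that something is new, unique, unknown or untested is made for them only; others in the source may bear on it.

Measured so far in a functional assay on CAL-51 cells (Homo sapiens) for antiproliferative activity, read by luminescence and CellTiter-Glo, with a stated time of 3 days; a lower number here means a stronger inhibitor, a higher number a weaker inhibitor:
Compound 1, `CN(C)C(=O)c1ccc(Nc2nc(O[C@H]3CC[C@@](C)(O)CC3)c3cc[nH]c3n2)c(OCC(F)(F)F)c1`, gives 15 nM.
Compound 2, `COc1cc(C(=O)N(C)C)ccc1Nc1nc(OC2COC2)c2cc[nH]c2n1`, gives 1960 nM.
Compound 3, `C[C@@H](Oc1cc(C(=O)N(C)C)ccc1Nc1nc(O[C@H]2CC[C@@](C)(O)CC2)c2c(Cl)c[nH]c2n1)C(F)(F)F`, gives 10 nM.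

Compound 2 stands highest of the three numbers in this assay; compound 1 and compound 3 both sit far lower, beyond the scatter, but each differs from compound 2 in more than one place, so no single step can be read from them.

Compound 4, `COc1cc(C(=O)N(C)C)ccc1Nc1nc(O[C@H]2CCOC(C)(C)C2)c2cc[nH]c2n1`, differs from compound 2 in one place: 2,2-dimethyloxan-4-yl in place of oxetan-3-yl on an oxygen on an aromatic ring. The entering group is a larger saturated ring, nearer in size to the ring ether carried by compound 1 and compound 3, which both give much lower numbers in this assay.

On that basis compound 4 is expected to improve on compound 2, with an expected step of a 6.5-fold lower number from compound 2 to compound 4 (0.82 log units; beyond the scatter) in this assay, clearly beyond the scatter. The estimate for compound 4 in this assay is 300 nM, with a range from 80 nM to 1200 nM.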

Compound 4, half-maximal inhibitory concentration: 131 nM
For compound 4 the middle estimate is 2.3-fold (0.36 log units) above the measured one, and the stated range covers the measured number.
By their numbers in this assay, from the lowest: compounds 3 and 1 (each within the scatter of the next); then compound 4; then compound 2.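

In this assay, within the data shown here, the ether on an oxygen on an aromatic ring proves to be a place where a single change moves the number strongly: 2,2-dimethyloxan-4-yl in place of oxetan-3-yl gives a 15-fold lower number from compound 2 to compound 4 (1.17 log units; beyond the scatter), the first step that can be read at one place. Both groups carry a ring oxygen and the same count of hydrogen-bond acceptors, so a ring ether as such does not fix the number; the two differ in ring size, in the two methyl groups and in a defined stereocentre. No measurement shown gives a cause for this step.

Open, on these data alone, is how the step divides between ring size and the two methyl groups, which the plain oxan-4-yl ether would separate. Also open, as far as these compounds go, is whether an amine such as piperidin-4-yl is tolerated at this place on the shared core.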